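A few compounds are considered here, and "the series" means these few. Any claim that something is new, unique, unknown or untested is made for them only; others in the source may bear on it.

Series on a shared core, compound 1 `COc1ccc(-c2nc3cc(C(F)(F)F)ccc3[nH]2)c(OC)c1`. In an ADME assay on Vero cells (Chlorocebus sabaeus) for cytotoxicity (on this read-out higher numbers stand for lower toxicity in this test and lower numbers for higher toxicity in this test), compound 1 gives > 100000 nM, which is a limit of the assay and not a number. Compound 3 `CCC(=O)Nc1ccc(-c2nc3cc(C(F)(F)F)ccc3n2C)cc1` in this assay likewise gives > 100000 nM, again a limit. For the measured compounds named here, compound 2 `COc1ccc(-c2nc3cc(C(F)(F)F)ccc3[nH]2)cc1` is thus the only member with an actual number: in this assay compound 2 gives 15000 nM. Going by the values given here, the single measured one-point step, an at least 6.6-fold lower number from compound 1 to compound 2 (0.82 log units; beyond the scatter), shows that losing a methoxy lowered the number by at least that much, so compound 2 sits at the toxic end of what has been seen.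

Compound 4 `O=C(CN1CCCC1)Nc1ccc(-c2nc3cc(C(F)(F)F)ccc3[nH]2)cc1` is not yet measured; from compound 2 it differs by (((pyrrolidin-1-yl)methyl)carbonyl)amino in place of methoxy on an aromatic carbon. Among the compounds with values here, no measured step covers this exact change, and compound 3, the nearest structural neighbour of compound 4, differs from compound 2 in more than one place. Compound 3 nonetheless sits at the limit of > 100000 nM in this assay, at which 2 of the 3 values shown sit. Because compound 3 sits at the limit of > 100000 nM in this assay, at which 2 of the 3 values shown sit, compound 4 is expected to move toward a higher number, a 4.7-fold higher number from compound 2 to compound 4 (0.67 log units; beyond the scatter), quite possibly as far as the limit. The estimate for compound 4 in this assay is 70000 nM, between 20000 nM and 200000 nM.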

Compound 4, half-maximal cytotoxic concentration: > 100000 nM
Compound 4 was reported as a limit (the forecaster's own chance of this, stated with the estimate: 55%); middle value at least 1.4-fold (0.15 log units) from the limit.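

The one-place step at this position, on an aromatic carbon para to a large group, is an at least 6.6-fold higher number from compound 2 to compound 4 (0.82 log units; beyond the scatter) in this assay, so the new side chain alone is enough to separate compound 4 from compound 2, a change that compound 3, differing in more than one place, could not isolate. Compound 4 gives a limit and not a number, and it sits with the other compounds at that limit: the limit of > 100000 nM in this assay, at which 3 of the 4 values shown sit. For the compounds shown here, the step is therefore a lower bound on the size of this change, and compound 2 remains the only member with an actual number.

Whether the amide carbonyl or the pyrrolidine ring accounts for the change stays open. A plain amino group, an acetamide or a piperidine in place of the pyrrolidine at this position would separate the two parts.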